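From Methoxycarbonyl to Ethoxycarbonyl: Expected Cytotoxicity Shift

The source may hold more compounds than are shown below. What is called first, only, known or untested is meant among the compounds shown, and "the series" means these compounds.

Compound 3 `COC(=O)c1ccc(NC(=O)CSc2snnc2-c2ccc(OC)cc2)c(Br)c1` gives 195000 nM in an ADME assay on MT4 cells (Homo sapiens) for cytotoxicity (on this read-out higher numbers stand for lower toxicity in this test and lower numbers for higher toxicity in this test), the higher of the two numbers reported, though the gap to compound 1 `O=C(CSc1snnc1-c1ccc(F)cc1F)Nc1ccccc1Br`, which gives 144000 nM in this assay, lies within the scatter. For compound 2 `Cc1ccc(NC(=O)CSc2snnc2-c2ccc(F)cc2F)c(Br)c1` the result in this assay is a limit, > 273000 nM, namely (the limit of > 273000 nM in this assay, at which 1 of the 3 values shown sits). Compound 4 `CCOC(=O)c1ccc(NC(=O)CSc2snnc2-c2ccc(OC)cc2)c(Br)c1` differs from compound 3 by methyl in place of hydrogen on a saturated chain carbon bound to an oxygen next to a carbonyl group. Among the compounds with values here, the only measured step with a methyl entering for a hydrogen, an at least 1.8-fold higher number from compound 1 to compound 2 (0.27 log units; that floor lies within the scatter), reached just a floor within the scatter, so no movement beyond the scatter is expected here either. Compound 4 is therefore expected to give 200000 nM in this assay, within a range from 100000 nM to 400000 nM. That estimate means an expected step of a 1.0-fold higher number from compound 3 to compound 4 (0.01 log units; within the scatter).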

Compound 4, half-maximal cytotoxic concentration: > 245000 nM
Compound 4: no number, only a limit (the forecaster's own chance of this, stated with the estimate: 30%); middle value at least 1.2-fold (0.08 log units) away from the limit.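

Compound 4 gives no number in this assay, only a limit: the limit of > 245000 nM in this assay, at which 1 of the 4 values shown sits.

Going from methoxycarbonyl to ethoxycarbonyl amounts to an at least 1.2-fold higher number from compound 3 to compound 4 (0.09 log units; that floor lies within the scatter). The earlier methyl step, an at least 1.8-fold higher number from compound 1 to compound 2 (0.27 log units; that floor lies within the scatter), lay on an aromatic carbon, and this one shows that on a saturated chain carbon bound to an oxygen next to a carbonyl group the same exchange also brings no lower number.

As far as these compounds go, how far compound 4 lies past its limit stays open. So does whether a longer chain, such as propoxycarbonyl, or a carboxylic acid at this place would read the same way.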